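Swapping the Aryl Group of Compound 1: an Expectation

A few compounds are considered here, and "the series" means these few. Any claim that something is new, unique, unknown or untested is made for them only; others in the source may bear on it.

Compound 1 `CC1=C(C(=O)OC(C)C)C(c2ccsc2)N/C(=N/C#N)N1`: 11%
Compound 2 `CCOC(=O)C1=C(C)N/C(=N\C#N)NC1c1ccsc1`: 29%

Both compounds were tested in an assay on cells for displacement of a labelled ligand from adenosine receptor A1 (Homo sapiens), with a stated time of 60 min, tested at 1 uM; a lower number here means less inhibition, a higher number more inhibition at the concentration tested (going by the name of the read-out). Compound 1 stands lowest of the two numbers; its nearest neighbour is compound 2, and the step of a number 18 percentage points higher from compound 1 to compound 2 (beyond the scatter). Compound 3 `CC1=C(C(=O)OC(C)C)C(c2ccco2)N/C(=N/C#N)N1` has not been measured; it differs from compound 1 by furan-2-yl in place of thiophen-3-yl on a saturated ring carbon. Within the data shown here, the one measured step concerns the ester and leaves the thiophen-3-yl group untouched, so no measured step bears on this change; with nothing to go on, no step beyond the scatter is expected, a number 1 percentage points higher from compound 1 to compound 3 (within the scatter). Compound 3 is therefore estimated at 12%, between 0% and 30%.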

Compound 3, a percentage reported as inhibition, at one concentration (the size of the read-out at that concentration, not a potency): 21%
Compound 3: the middle estimate sits 9 percentage points below what was measured; measured number inside the range.
By their numbers in this assay, from the lowest: compounds 1, 3 and 2 (each within the scatter of the next, the first and the last beyond it).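

In this assay, among these compounds, the change from thiophen-3-yl to furan-2-yl on the saturated ring carbon gives a number 10 percentage points higher from compound 1 to compound 3 (within the scatter) and is the first reading at this position. With the isopropoxycarbonyl group kept, one five-membered aromatic ring can therefore take the place of the other without a step beyond the scatter. No measurement at hand accounts for this result.

The compounds shown leave open whether a phenyl or a cyclohexyl group on this carbon would give a step beyond the scatter. They also leave open whether furan-2-yl gives the same result alongside the ethyl ester of compound 2.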